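Ring size at the amide and cell growth inhibition

The source may report more compounds than this note shows. Statements on the series, on what has been measured and on what is new or still open speak of the compounds shown alone.

For the measured compounds named here, compound 2 `COc1cc(-n2cccc2C(=O)N2CCCC2)ccc1Nc1ncc(Cl)c(Nc2ccccc2NS(C)(=O)=O)n1` is the only member of this set with a numerical result: in a functional assay on A549 cells (Homo sapiens) for antiproliferative activity, read by MTT assay, with a stated time of 72 h (a higher number here means a weaker inhibitor, a lower number a stronger inhibitor), compound 2 gives 4580 nM. Compound 1 `CCN1CCN(C(=O)c2cccn2-c2ccc(Nc3ncc(Cl)c(Nc4ccccc4NS(C)(=O)=O)n3)c(OC)c2)CC1` reaches only the limit of this assay, > 10000 nM, so no exact number is known for it. Going by the values given here, the one measured step, an at least 2.1-fold lower number from compound 1 to compound 2 (0.33 log units; beyond the scatter), therefore cannot be sized exactly and rests on (the limit of > 10000 nM in this assay, at which 1 of the 2 values shown sits). Compound 3 `COc1cc(-n2cccc2C(=O)N2CCC(C)CC2)ccc1Nc1ncc(Cl)c(Nc2ccccc2NS(C)(=O)=O)n1` differs from compound 2 at the same carbonyl carbon: 4-methylpiperidin-1-yl in place of pyrrolidin-1-yl on a carbonyl carbon. Among the compounds with values here, the single step that bears on this change is the one from compound 1 to compound 2, which shows that exchanging the ring amine on that carbonyl carbon can move the result beyond the scatter, but it involved a different pair of rings, and the enlargement from a five-membered to a six-membered ring has no direct precedent here. For compound 3 a step of a 1.3-fold lower number from compound 2 to compound 3 (0.12 log units; within the scatter) is expected, close to no change beyond the scatter. Compound 3 is estimated at 3500 nM, within a range from 1000 nM to 12000 nM.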

Compound 3, half-maximal inhibitory concentration: 2200 nM
Beside the measured number, compound 3's estimate is 1.6-fold (0.20 log units) above it; the measured number falls inside the stated range.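

In this assay the amide ring now has a step between two exact numbers, a 2.1-fold lower number from compound 2 to compound 3 (0.32 log units; beyond the scatter), so replacing pyrrolidin-1-yl with 4-methylpiperidin-1-yl on a carbonyl carbon moves the result beyond the scatter rather than leaving it unchanged. With this step, compound 3 is the strongest inhibitor of the three shown, and all three differ only in the ring amine on that carbonyl carbon, so this one place can carry differences in cell growth inhibition in both of the steps that have been read. The wider step, an at least 4.5-fold lower number from compound 1 to compound 3 (0.65 log units; beyond the scatter), has only a lower bound on its size and no exact value, because compound 1 is a limit and not a number: the limit of > 10000 nM in this assay, at which 1 of the 3 values shown sits.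

The change to compound 3 enlarges the ring and adds a methyl group at once, so the compounds shown cannot separate these two parts, and the unsubstituted piperidin-1-yl group would be needed to tell them apart. From the compounds shown here alone, it also remains open how other groups at this place would behave, such as morpholin-4-yl, a longer chain at the 4-position of the piperidine, or a carboxylic acid there.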